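Shortening the Side Chain: Butylsulfanyl Gives Way to Methoxy

The source may hold more compounds than are shown below. What is called first, only, known or untested is meant among the compounds shown, and "the series" means these compounds.

Of the compounds shown here, three sharing one core have been tested in a functional assay on the whole organism for activation, with Mus musculus as the target; on this read-out higher numbers stand for an effect only at larger amounts of compound and lower numbers for an effect already at smaller amounts. Compound 1 `Cc1nc(N)c2nc(O)n(Cc3ccccc3)c2n1` gives 3 mg/kg. Compound 2 `Nc1nc(O)nc2c1nc(O)n2Cc1ccccc1`, with hydroxy in place of methyl, gives 1 mg/kg, a step of a 3.0-fold lower number from compound 1 to compound 2 (0.48 log units; beyond the scatter). Compound 3 `CCCCSc1nc(N)c2nc(O)n(Cc3ccccc3)c2n1` gives 0.3 mg/kg and holds the lowest number of the three: it is reached by a 10-fold lower number from compound 1 to compound 3 (1.00 log units; beyond the scatter) and by a 3.3-fold lower number from compound 2 to compound 3 (0.52 log units; beyond the scatter), both beyond the scatter, so compound 3 acts at the smallest dose seen so far.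

Compound 4 `COc1nc(N)c2nc(O)n(Cc3ccccc3)c2n1` differs from compound 3 at one place: methoxy in place of butylsulfanyl on an aromatic carbon. Among the compounds with values here, no measured pair swaps methoxy for another group, so the nearest guides are the two steps that put butylsulfanyl in place of a small group, methyl in a 10-fold lower number from compound 1 to compound 3 (1.00 log units; beyond the scatter) and hydroxy in a 3.3-fold lower number from compound 2 to compound 3 (0.52 log units; beyond the scatter). Both show the butylsulfanyl compound at the lowest number, and the entering methoxy, as the counts show, is far nearer in size to methyl or hydroxy than to the group it replaces. Taking butylsulfanyl away is therefore expected to raise the number, landing compound 4 near where compounds 1 and 2 sit. The expected step is a 5.0-fold higher number from compound 3 to compound 4 (0.70 log units; beyond the scatter). Compound 4 is estimated at 1.5 mg/kg, with a range from 0.5 mg/kg to 5 mg/kg.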

Compound 4, minimum effective dose: > 1 mg/kg
Compound 4 gave a limit, no number; the forecaster's own chance of this, stated with the estimate: 5%; the middle value is on the limit's open side.
By their numbers in this assay, from the lowest: compound 3; then compound 2; then compound 1.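

In this assay compound 4 carries > 1 mg/kg, which is a limit of the assay and not a number. Even so, the limit is enough to show that the low dose of compound 3 does not carry over to every group attached through a single atom at this carbon between two ring nitrogen atoms: the change from butylsulfanyl to methoxy, which leaves the printed counts of hydrogen-bond donors and acceptors the same, gives an at least 3.3-fold higher number from compound 3 to compound 4 (0.52 log units; beyond the scatter). Capping the hydroxy of compound 2 with methyl gives a number no lower from compound 2 to compound 4 (the limit leaves the size open), so this small change brings no gain, while the size of that step and the step from compound 1 to compound 4 cannot be read.

The shown compounds do not separate the length of the chain from the identity of the linking atom, since butylsulfanyl differs from methoxy in both. Butoxy would keep the chain and swap the sulfur for oxygen, and methylsulfanyl would keep the sulfur and shorten the chain, so these two groups would tell the two apart.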